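Working notes on compound 4 against compound 1

This account rests on a few compounds, and the source may have more. Where it says the series, first, only, none or still open, it means among the compounds named here.

For the measured compounds named here, compound 1 `Cc1ccc(S(=O)(=O)NC(=O)/C=C/c2ccccc2)cc1` gives 13.8 ug/mL in a functional assay on B16-F10 cells (Mus musculus) for antiproliferative activity, read by ELISA and MTT assay, with a stated time of 48 h (on this read-out higher numbers stand for weaker inhibition and lower numbers for stronger inhibition), the highest of the three numbers so far. Compound 2 `O=C(/C=C/c1ccccc1)NS(=O)(=O)c1ccc(F)cc1` gives 2.1 ug/mL and compound 3 `O=C(/C=C/c1ccccc1)NS(=O)(=O)c1ccc(Br)cc1` gives 3.9 ug/mL; the measured steps are a 6.6-fold lower number from compound 1 to compound 2 (0.82 log units; beyond the scatter), a 3.5-fold lower number from compound 1 to compound 3 (0.55 log units; beyond the scatter) and a 1.9-fold higher number from compound 2 to compound 3 (0.27 log units; within the scatter). Compound 4 `Cc1ccc(S(=O)(=O)NC(=O)/C=C/c2ccc(Cl)cc2)cc1` differs from compound 1 by chloro in place of hydrogen on an aromatic carbon. Going by the values given here, this change falls on a different part of the structure from the changes seen in compounds 2 and 3, so none of the measured steps bears on it directly. Among the compounds with values here, both steps away from compound 1 did move the number down, but that offers no precedent for this change. Compound 4 is expected to show a 1.4-fold lower number from compound 1 to compound 4 (0.14 log units; within the scatter), a step within the scatter. Compound 4 is therefore estimated at 10 ug/mL in this assay, with a range of 4 ug/mL to 30 ug/mL.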

Compound 4, half-maximal inhibitory concentration: 4.6 ug/mL
For compound 4 the middle estimate is 2.2-fold (0.34 log units) above the measured one; measured number inside the range.
By their numbers in this assay, from the lowest: compounds 2, 3 and 4 (each within the scatter of the next, the first and the last beyond it); then compound 1.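

In this assay, phenyl to 4-chlorophenyl gives a 3.0-fold lower number from compound 1 to compound 4 (0.48 log units; beyond the scatter). The number therefore responds to substitution on this ring as well as to the changes at the methyl position seen in compounds 2 and 3, and chloro para to a large group is tolerated with a lower number. Nothing measured here accounts for the size of this step.

On these data alone, it remains open whether an amine, a carboxylic acid or a methoxy group at this place would move the number in the same direction. Also open, as far as these compounds go, is whether fluoro or bromo here would match chloro.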